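The source may hold more compounds than are shown below. What is called first, only, known or untested is meant among the compounds shown, and "the series" means these compounds.

Of the compounds shown here, three have been measured in a functional assay on the whole organism (Tail, strain ICR) with Mus musculus as the target, in the tail flick test, with a stated time of 30 min, at a dose of 25 umol/kg by the oral route; on this read-out higher numbers stand for a stronger effect at the one dose given and lower numbers for a weaker effect. Compound 1 `N=C(N)NCCC[C@H](NC(=O)CN(c1nc(Cl)nc2[nH]cnc12)C1CC1)C(=O)OCc1ccccc1` gives 23.2% in this assay. Compound 2 `O=C(O)C[C@H](NC(=O)CN(c1nc(Cl)nc2[nH]cnc12)C1CC1)C(=O)O` gives 19.9% in this assay, and compound 3 `O=C(CN(c1ncnc2c1ncn2C1CCCCO1)C1CC1)N[C@@H](CCC(=O)OCc1ccccc1)C(=O)OCc1ccccc1` gives 32.6% in this assay. Going by the values given here, of these three numbers the one for compound 1 sits second highest, yet its gap to compound 2 and its gap to compound 3 both fall within the usual scatter, so the three read-outs cannot be told apart with confidence.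

Compound 4 `C[C@@H](O)[C@H](NC(=O)CN(c1nc(Cl)nc2[nH]cnc12)C1CC1)C(=O)OCc1ccccc1` has not been measured. It differs from compound 1 in one place: a group of 3 heavy atoms (2 carbon, 1 oxygen; no ring) in place of a group of 7 heavy atoms (4 carbon, 3 nitrogen; no ring), on a saturated chain carbon bound to an amide-type nitrogen and a carbonyl carbon

Among the compounds with values here, no pair of measured compounds differs in a single place, so no measured step guides the expectation. The three numbers in hand all lie within the scatter of one another across rather different side chains, and on that basis the step of a number 1.2 percentage points lower from compound 1 to compound 4 (within the scatter) is expected to stay within the scatter, with no clear direction. Compound 4 is therefore estimated to give 22% in this assay, within a range of 10% to 34%.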

Compound 4, a percentage reported as activity, at one dose (the size of the read-out at that dose, not a potency): 21.9%
Estimate against measurement, compound 4: 0.1 percentage points above, and the stated range covers the measured number.
By their numbers in this assay, from the lowest: compounds 2, 4, 1 and 3 (each within the scatter of the next, the first and the last beyond it).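

Going by these compounds alone, on the saturated chain carbon bound to an amide-type nitrogen and a carbonyl carbon, placing 1-hydroxyethyl in the stead of the group of 7 heavy atoms gives [ a number 1.3 percentage points lower from compound 1 to compound 4 (within the scatter) ] in this assay, the first comparison in which only one place changes. With the rest of compound 1 held fixed, this read-out therefore does not separate the two groups, although the group's hydrogen-bond donors go from 3 to 1 and its nitrogen atoms are lost altogether. Nothing measured here offers an explanation for this result.

The compounds shown leave open whether a primary amine or a longer alkyl chain on this carbon would move the read-out beyond the scatter. They also leave open whether compound 1 and compound 4 would stay together at other doses.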